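Methoxy in place of hydrogen on compound 1

The source may hold more compounds than are shown below. What is called first, only, known or untested is meant among the compounds shown, and "the series" means these compounds.

Among the measured compounds shown here, in an ADME assay on PBMC cells (Homo sapiens) for inhibition, read by MTT assay (a higher number here means a weaker inhibitor, a lower number a stronger inhibitor), compound 1 `CC1=CCC[C@H]2[C@](C)(CC3=CC(=O)C=CC3=O)[C@@H](C)CC[C@]12C` gives 4500 nM as the only number so far. For the measured compounds named here, compound 2 `CC1=CCC[C@H]2[C@](C)(CC3=CC(=O)C(SC(C)C)=CC3=O)[C@@H](C)CC[C@]12C` gives "not determined" (no result reported), so no measured step is available as a guide. Compound 3 `COC1=CC(=O)C=C(C[C@]2(C)[C@@H](C)CC[C@]3(C)C(C)=CCC[C@@H]23)C1=O` differs from compound 1 by one change methoxy in place of hydrogen on a double-bonded ring carbon with methoxy in place of hydrogen on a double-bonded ring carbon. The expected 1.3-fold higher number from compound 1 to compound 3 (0.12 log units; within the scatter) in this assay is small and probably within the scatter, with a slight lean toward weaker inhibition. For compound 3 the estimate is 6000 nM with an expected range from 2000 nM to 18000 nM at this stage.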

Compound 3, half-maximal inhibitory concentration: 5500 nM
Compound 3: the middle estimate sits 1.1-fold (0.04 log units) above what was measured, within the range that was stated.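

Methoxy in place of hydrogen on the double-bonded ring carbon gives a 1.2-fold higher number from compound 1 to compound 3 (0.09 log units; within the scatter) in this assay, the first measured step at this position. This position therefore accepts methoxy with no change beyond the scatter, something compound 2, which has no number, could not show. Nothing measured here bears on why the step is so small. Open, going by these compounds, is whether an amine or a carboxylic acid on this ring carbon would move the number beyond the scatter. On these data alone, a longer chain joined through the same oxygen also remains open.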